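From Oxan-4-yl to an Open Chain

The source may report more compounds than this note shows. Statements on the series, on what has been measured and on what is new or still open speak of the compounds shown alone.

In a physicochemical assay for lipophilicity (on this read-out higher numbers stand for higher lipophilicity and lower numbers for lower lipophilicity), compound 1 `O=C(CN(C(=O)c1ccc(-c2ccccn2)cc1)C1CCCCC1)Nc1cc(F)cc(F)c1` reads 3.7, compound 2 `O=C(CN(C(=O)c1ccc(-c2ccccn2)cc1)C1CCCOC1)Nc1cc(F)cc(F)c1` reads 2.7 and compound 3 `O=C(CN(C(=O)c1ccc(-c2ccccn2)cc1)C1CCOCC1)Nc1cc(F)cc(F)c1` reads 2.5. Compound 3 thus stands within the usual scatter of compound 2 and clearly under compound 1. Compound 4 `COCC(C)N(CC(=O)Nc1cc(F)cc(F)c1)C(=O)c1ccc(-c2ccccn2)cc1` differs from compound 3 in one place: 1-(methoxymethyl)ethyl in place of oxan-4-yl on an amide-type nitrogen. For the measured compounds named here, no measured step opens a ring, so the evidence is indirect. Replacing cyclohexyl gave sizeable changes, a number 1.00 log units lower from compound 1 to compound 2 (beyond the scatter) and a number 1.20 log units lower from compound 1 to compound 3 (beyond the scatter). Exchanging one oxygen-bearing group for another gave only a number 0.20 log units lower from compound 2 to compound 3 (within the scatter), and this is the closest guide. No step beyond the scatter is therefore expected, with the estimate being a number 0.10 log units higher from compound 3 to compound 4 (within the scatter). For compound 4 the estimated value is 2.6, with an expected range of 2.2 to 3.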

Compound 4, distribution coefficient: 3
Estimate against measurement, compound 4: 0.40 log units below; measured number inside the range.
By their numbers in this assay, from the lowest: compounds 3, 2 and 4 (each within the scatter of the next, the first and the last beyond it); then compound 1.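

Moving to the open chain on this amide-type nitrogen gives a number 0.50 log units higher from compound 3 to compound 4 (beyond the scatter) in this assay and so separates two oxygen-bearing groups, which the exchange of oxan-3-yl for oxan-4-yl had not done. The same change gives a number 0.30 log units higher from compound 2 to compound 4 (within the scatter) and leaves the chain clearly short of cyclohexyl, with a number 0.70 log units lower from compound 1 to compound 4 (beyond the scatter) as the step. No measurement here accounts for the shift.

The compounds shown leave open whether the loss of the ring or the branching of the chain matters. On these data alone, how a straight 2-methoxyethyl chain or an amine such as piperidin-4-yl would read at this nitrogen also remains open.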